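This account rests on a few compounds, and the source may have more. Where it says the series, first, only, none or still open, it means among the compounds named here.

Compound 1 `CCn1c(C(=O)N[C@@H](C)C(=O)OC)ccc1C(CC)(CC)c1ccc(OCS(=O)(=O)c2ccccc2)c(C)c1`: > 50000 nM
Compound 2 `CCn1c(C(=O)N[C@@H](CC(=O)OC)C(=O)OC)ccc1C(CC)(CC)c1ccc(OCS(=O)(=O)c2ccccc2)c(C)c1`: 6490 nM

In a functional assay on PC-3 cells (Homo sapiens) for antiproliferative activity, read by MTT assay, with a stated time of 24 h (a higher number here means a weaker inhibitor, a lower number a stronger inhibitor), compound 1 reaches only the limit > 50000 nM, so its standing is a limit, not a number, as the limit of > 50000 nM in this assay, at which 1 of the 2 values shown sits, shows. Compound 2 gives 6490 nM in this assay. Among the compounds with values here, the one measured step, an at least 7.7-fold lower number from compound 1 to compound 2 (0.88 log units; beyond the scatter), is a different change from the one leading to compound 3 `CCn1c(C(=O)N[C@H](C(=O)O)C(C)C)ccc1C(CC)(CC)c1ccc(OCS(=O)(=O)c2ccccc2)c(C)c1`, which carries 1-carboxy-2-methylpropyl in place of 1-(methoxycarbonyl)ethyl on an amide-type nitrogen. Within the data shown here, no measured step covers this change, so the estimate rests on compound 1 alone. Compound 3 is expected at 30000 nM, between 6000 nM and 100000 nM, an estimated step of an at least 1.6-fold lower number from compound 1 to compound 3 (0.22 log units; that floor lies within the scatter) that may well stay at the limit.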

Compound 3, half-maximal inhibitory concentration: 3650 nM
Compound 3: the middle estimate sits 8.2-fold (0.91 log units) above what was measured; measured number below the stated range.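

At this amide-type nitrogen in this assay, 1-carboxy-2-methylpropyl in place of 1-(methoxycarbonyl)ethyl gives an at least 13-fold lower number from compound 1 to compound 3 (1.13 log units; beyond the scatter). That step has only a floor, as compound 1 stands at a limit: the limit of > 50000 nM in this assay, at which 1 of the 3 values shown sits. A carboxy-bearing group and 1,2-bis(methoxycarbonyl)ethyl cannot be told apart on this nitrogen, with a 1.8-fold lower number from compound 2 to compound 3 (0.25 log units; within the scatter).

The step from compound 1 alters both the chain and the methoxycarbonyl group, and the compounds shown do not separate these two changes. Going by these compounds, whether a primary amide or an amine on this chain would match the carboxy group also remains open.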